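The source may hold more compounds than are shown below. What is called first, only, known or untested is meant among the compounds shown, and "the series" means these compounds.

Three amides built on a shared core have been tested in a functional assay on A549 cells (Homo sapiens) for cytotoxicity, read by MTT assay, with a stated time of 24 h; a lower number here means a stronger inhibitor, a higher number a weaker inhibitor. Compound 1 `C=CC1=C(C(=O)NCCCCC)C(c2ccc(Cl)c(Cl)c2)OC1` carries a pentyl chain on the amide-type nitrogen; in this assay compound 1 gives > 100000 nM, which is a limit of the assay rather than a number. Compound 2 `C=CC1=C(C(=O)NCC(C)C)C(c2ccc(Cl)c(Cl)c2)OC1` carries an isobutyl group on that nitrogen; in this assay compound 2 gives > 100000 nM, again a limit. Compound 3 `C=CC1=C(C(=O)Nc2ccccc2)C(c2ccc(Cl)c(Cl)c2)OC1` carries a phenyl group on that nitrogen; in this assay compound 3 gives > 100000 nM, also a limit. The steps between them are therefore not readable: a step that the two limits leave unreadable from compound 1 to compound 2, a step that the two limits leave unreadable from compound 1 to compound 3 and a step that the two limits leave unreadable from compound 2 to compound 3. All three sit at the limit of > 100000 nM in this assay, at which 3 of the 3 values shown sit.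

Compound 4 `C=CC1=C(C(=O)O)C(c2ccc(Cl)c(Cl)c2)OC1` differs from compound 3 by hydroxy in place of anilino on a carbonyl carbon, so the amide becomes a carboxylic acid. Going by the values given here, none of the measured steps touches this change, and none has a readable size, so no direction can be read from them. Compound 4 is expected to remain at the limit, estimated at 150000 nM with a range from 50000 nM to 600000 nM. This estimate means an expected step that the limit leaves unreadable from compound 3 to compound 4.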

Compound 4, half-maximal inhibitory concentration: > 100000 nM
Compound 4: only a limit was reported (the forecaster's own chance of this, stated with the estimate: 85%); the middle value does not contradict the limit.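

In this assay compound 4 gives > 100000 nM, which is a limit and not a number, so its steps from compound 1, compound 2 and compound 3 cannot be read. The compounds shown leave open whether any of these groups on the carbonyl carbon changes the result at all, as every compound sits at the same limit: the limit of > 100000 nM in this assay, at which 4 of the 4 values shown sit.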